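Swapping the Pyrazine Amide for a Methoxyacetamide

The source may hold more compounds than are shown below. What is called first, only, known or untested is meant among the compounds shown, and "the series" means these compounds.

Of the compounds shown here, three sharing one core have been tested in a functional assay on KBVIN cells (Homo sapiens) for antiproliferative activity, read by sulforhodamine B assay, with a stated time of 3 days; a higher number here means a weaker inhibitor of growth, a lower number a stronger inhibitor of growth. Compound 1 `O=C(c1cccc(Nc2ncc(F)c(Nc3ccc(F)cc3)n2)c1)N1CCCCC1` gives 13800 nM. For the measured compounds named here, compound 2 `Cn1ccnc1NC(=O)c1cccc(Nc2ncc(F)c(Nc3ccc(F)cc3)n2)c1` gives 13100 nM; the single exchange between the two reads a 1.1-fold lower number from compound 1 to compound 2 (0.02 log units; within the scatter). Compound 3 `O=C(Nc1cccc(Nc2ncc(F)c(Nc3ccc(F)cc3)n2)c1)c1cnccn1` gives 20100 nM. Compound 3 shows the highest number of the three, yet its distance to the others, a 1.5-fold higher number from compound 1 to compound 3 (0.16 log units; within the scatter) and a 1.5-fold higher number from compound 2 to compound 3 (0.19 log units; within the scatter), lies within the scatter, so the three cannot be put in order.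

Compound 4 `COCC(=O)Nc1cccc(Nc2ncc(F)c(Nc3ccc(F)cc3)n2)c1` differs from compound 3 in one place: methoxymethyl in place of pyrazin-2-yl on a carbonyl carbon. Going by the values given here, no measured step exchanges the group on this carbonyl carbon; the two steps leading to compound 3 rebuilt the amide itself and stayed within the scatter. The measured data therefore give no basis for a shift beyond the scatter in this assay, and the expectation is a number close to that of compound 3.

Compound 4 is estimated to give 18000 nM, within a range from 7000 nM to 45000 nM. This estimate corresponds to an expected step of a 1.1-fold lower number from compound 3 to compound 4 (0.05 log units; within the scatter), which would remain within the scatter.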

Compound 4, concentration for 50% growth inhibition: 3940 nM
The estimate for compound 4 lay 4.6-fold (0.66 log units) above the measured number, and the stated range ends above it.
By their numbers in this assay, from the lowest: compound 4; then compounds 2, 1 and 3 (each within the scatter of the next).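

In this assay, for the compounds shown here, the group on the carbonyl carbon turns out to count: methoxymethyl in place of pyrazin-2-yl gives a 5.1-fold lower number from compound 3 to compound 4 (0.71 log units; beyond the scatter) and is the first exchange here to go beyond the scatter. Compound 4 also separates from the other two, with a 3.3-fold lower number from compound 2 to compound 4 (0.52 log units; beyond the scatter) and with a 3.5-fold lower number from compound 1 to compound 4 (0.54 log units; beyond the scatter) as well, so a chain without a ring at this place sets it apart from three compounds that could not be put in order. Nothing measured here explains this shift.

The compounds shown cannot tell whether the result depends on the oxygen of methoxymethyl or only on the loss of the aromatic ring. A plain methyl, a longer methoxyethyl chain or a dimethylaminomethyl amine on the same carbonyl carbon would separate these readings.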